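The source may hold more compounds than are shown below. What is called first, only, known or untested is meant among the compounds shown, and "the series" means these compounds.

Measured in a functional assay on CHO cells for agonist activity at metabotropic glutamate receptor 2 (Homo sapiens), read by GTPgammaS binding; a higher number here means a larger maximal response, a lower number a smaller maximal response:
compound 1 `CCCn1ccc2cc(N3CCC(O)CC3)cc(Cl)c2c1=O`: 106%
compound 2 `CCCn1ccc2cc(-c3cncnc3)cc(Cl)c2c1=O`: 28%
compound 3 `CCCn1ccc2cc(OCc3cccnc3)cc(Cl)c2c1=O`: 126%

Compound 3 gives the highest of the three numbers in this assay; compound 1 sits below it beyond the scatter, and compound 2 lies furthest below it. Compound 4 `CCCn1ccc2cc(OCCCc3cccnc3)cc(Cl)c2c1=O` is compound 3 with 2-(pyridin-3-yl)ethyl in place of pyridin-3-yl on a saturated chain carbon bound to an oxygen on an aromatic ring. Among the measured compounds shown here, the only step measured so far, a number 78 percentage points lower from compound 1 to compound 2 (beyond the scatter), exchanges the group bound directly to the aromatic carbon and therefore does not bear on lengthening the chain between the ring oxygen and the pyridine. For the measured compounds named here, no measured pair addresses such a chain extension, so the expectation rests on compound 3 alone, with wide uncertainty. The expected step is a number 26 percentage points lower from compound 3 to compound 4 (beyond the scatter), a modest fall in maximal response. For compound 4 the estimate is 100%, with a range from 50% to 135%.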

Compound 4, largest response reached (Emax), in percent of the reference or control that the assay uses: 75%
Beside the measured number, compound 4's estimate is 25 percentage points above it, within the range that was stated.
By their numbers in this assay, from the lowest: compound 2; then compound 4; then compound 1; then compound 3.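

In this assay, the response depends on chain length as well as on the group bound directly to the aromatic carbon: 2-(pyridin-3-yl)ethyl in place of pyridin-3-yl on a saturated chain carbon bound to an oxygen on an aromatic ring gives a number 51 percentage points lower from compound 3 to compound 4 (beyond the scatter). The pyridine ring and the hydrogen-bond donor and acceptor counts stay the same across this change, so the large step comes with the added chain alone. No available data explain the fall. Still open, on these data alone, is whether a longer chain lowers the response further. Also open, as far as these compounds go, is how a morpholine or a primary amine would behave in place of the pyridine on this chain.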